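A few compounds are considered here, and "the series" means these few. Any claim that something is new, unique, unknown or untested is made for them only; others in the source may bear on it.

Measured compounds:
- Compound 1, `CC[C@@H]1C(=O)N(C)c2cnc(Nc3ccc(S(=O)(=O)NC4CCCC4)cc3)nc2N1C1CCCC1`: 872 nM
- Compound 2, `CC[C@@H]1C(=O)N(C)c2cnc(Nc3ccc(S(N)(=O)=O)cc3)nc2N1C1CCCC1`: 470 nM
- Compound 3, `CCC1C(=O)N(C)c2cnc(Nc3ccc(S(=O)(=O)NCCCO)cc3)nc2N1c1ccn(C)n1`: 13400 nM

All three were tested in a functional assay on K562 cells (Homo sapiens) for antiproliferative activity, read by CCK-8 assay, with a stated time of 72 h; on this read-out lower numbers stand for stronger inhibition of growth and higher numbers for weaker inhibition of growth. Compound 3 gives the highest number of the three; compound 1 and compound 2 both give clearly lower numbers, and both gaps lie beyond the usual scatter. Compound 3 also differs from the other two in more than one place, so its higher number cannot be tied to any single feature.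

Compound 4, `CCCCNS(=O)(=O)c1ccc(Nc2ncc3c(n2)N(c2ccn(C)n2)C(CC)C(=O)N3C)cc1`, is the unmeasured partner of compound 3. The two differ in one place: methyl in place of hydroxy on a saturated chain carbon, three bonds along the chain from a sulfonamide nitrogen.

Among the compounds with values here, only one measured step speaks to changes around the sulfonamide, a 1.9-fold lower number from compound 1 to compound 2 (0.27 log units; within the scatter). That change sat directly on the sulfonamide nitrogen, removed a whole ring, and still left the number within the scatter. The change from compound 3 to compound 4 is smaller and sits further out along the chain. Nothing measured here separates a hydroxy from a methyl at that position. On that basis no step beyond the scatter is expected from compound 3 to compound 4 in this assay.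

For compound 4 the expected value is 11000 nM, with a range from 4000 nM to 30000 nM, which means an estimated step of a 1.2-fold lower number from compound 3 to compound 4 (0.09 log units; within the scatter).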

Compound 4, concentration for 50% growth inhibition: 4240 nM
For compound 4 the middle estimate is 2.6-fold (0.41 log units) above the measured one, and the stated range covers the measured number.
By their numbers in this assay, from the lowest: compounds 2 and 1 (each within the scatter of the next); then compound 4; then compound 3.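

In this assay, methyl in place of hydroxy on a saturated chain carbon, three bonds along the chain from a sulfonamide nitrogen, gives a 3.2-fold lower number from compound 3 to compound 4 (0.50 log units; beyond the scatter), a modest step but one that clears the usual scatter. Within the data shown here, this is the first change around the sulfonamide in these compounds to do so: the only earlier step, a 1.9-fold lower number from compound 1 to compound 2 (0.27 log units; within the scatter), took a whole cyclopentyl ring off the sulfonamide nitrogen and stayed within the scatter, whereas swapping a single heavy atom at the far end of the chain, 3-hydroxypropyl to butyl, does move the number, so this outer position cannot be treated as indifferent. The swap removes a hydroxy, with its hydrogen-bond donor and acceptor, but nothing given here measures any property that would explain the step.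

An amine or a carboxylic acid in place of the hydroxy, or a chain longer than butyl, would help show whether the number follows the loss of the hydroxy or the nature of the chain end more generally. Going by these compounds, it also remains open whether the same swap would give a step of similar size on a compound carrying the cyclopentyl group of compound 1 in place of the group that compound 3 and compound 4 share.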